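A few compounds are considered here, and "the series" means these few. Any claim that something is new, unique, unknown or untested is made for them only; others in the source may bear on it.

Measured compounds:
Compound 1 `COc1ncc(-c2ccc3c(c2)NC(=O)CO3)cc1NS(=O)(=O)c1ccc(F)cc1` gives 26300 nM
Compound 2 `COc1ncc(-c2ccc3c(c2)N(c2ccccc2)C(=O)CO3)cc1NS(=O)(=O)c1ccc(F)cc1` gives 15200 nM

Both values come from a functional assay on A-375 cells (Homo sapiens) for antiproliferative activity, read by MTT assay, with a stated time of 72 h; on this read-out lower numbers stand for stronger inhibition and higher numbers for weaker inhibition. For the measured compounds named here, only two numbers are available, and compound 1 has compound 2 as its sole neighbour. The two lie within the scatter of each other, with the measured step being a 1.7-fold lower number from compound 1 to compound 2 (0.24 log units; within the scatter).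

Compound 3 `O=C1COc2ccc(-c3cnc(Cl)c(NS(=O)(=O)c4ccc(F)cc4)c3)cc2N1` keeps the core of compound 1 but has chloro in place of methoxy on an aromatic carbon, next to the ring nitrogen (chloro in place of methoxy on an aromatic carbon). Going by the values given here, the only measured step, a 1.7-fold lower number from compound 1 to compound 2 (0.24 log units; within the scatter), is phenyl in place of hydrogen on an amide-type nitrogen in a ring. It lies within the scatter and occurs at another place in the structure, so it bears on this change only indirectly. Among the compounds with values here, no measured compound varies the methoxy group, so the data give no direction for the exchange. No shift beyond the scatter is therefore expected, though the uncertainty is wide. The expected step is a 1.2-fold lower number from compound 1 to compound 3 (0.08 log units; within the scatter). For compound 3 the estimated value is 22000 nM, with an expected range from 7000 nM to 60000 nM.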

Compound 3, half-maximal inhibitory concentration: > 40000 nM
Compound 3 gave a limit, no number; the forecaster's own chance of this, stated with the estimate: 15%; at least 1.8-fold (0.25 log units) between middle value and limit.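

For the compounds shown here, this change is the first variation at this position, on an aromatic carbon next to the ring nitrogen, which the earlier compounds left untouched. Compound 3 gave a limit rather than a number in this assay: the limit of > 40000 nM in this assay, at which 1 of the 3 values shown sits. Chloro in place of methoxy therefore gives an at least 1.5-fold higher number from compound 1 to compound 3 (0.18 log units; that floor lies within the scatter), so the direction is upward, but the reading cannot separate a change within the scatter from a much larger loss, and it shows only that this exchange brought no measurable gain in antiproliferative activity over the shared core.

The compounds shown leave open how far compound 3 actually lies from compound 1, and whether the methoxy oxygen or simply the size of the group matters here, a question that an amine, a hydrogen or a longer chain such as ethoxy at this place would address. They also leave open whether the exchange would read the same way with phenyl on the ring amide nitrogen, as in compound 2, since only the core of compound 1 carries chloro here.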